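A few compounds are considered here, and "the series" means these few. Any claim that something is new, unique, unknown or untested is made for them only; others in the source may bear on it.

Compound 1 `COc1ccc2oc(/C=C/c3ccc(OC(F)(F)F)cc3)cc(=O)c2c1`: > 40000 nM
Compound 2 `COc1cc(OC)c2c(=O)cc(/C=C/c3ccc(OCC4CC4)cc3)oc2c1`: 22100 nM
Compound 3 `COc1cccc2oc(/C=C/c3ccc(OC(F)(F)F)cc3)cc(=O)c12`: 21000 nM

Of the compounds shown here, three built on a shared core have been measured in a functional assay on SKHep cells (Homo sapiens) for antiproliferative activity, read by MTT assay, with a stated time of 12 h; a higher number here means a weaker inhibitor, a lower number a stronger inhibitor. Compound 1 gives only a limit of this assay, > 40000 nM, so no number is known for it; this is the limit described by the limit of > 40000 nM in this assay, at which 1 of the 3 values shown sits. Compound 2 gives 22100 nM in this assay. Compound 3 gives 21000 nM in this assay. Going by the values given here, these two numbers lie within the scatter of each other, so compound 2 stands alongside compound 3 among the two numbers known, while compound 1 sits at the limit. Among the compounds with values here, no two of the measured compounds differ in only one place, so no single step has been measured here.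

Compound 4 `COc1cc(OC)c2c(=O)cc(/C=C/c3ccc(F)cc3)oc2c1` has not yet been measured in this assay. It differs from compound 2 by fluoro in place of cyclopropylmethoxy on an aromatic carbon. Within the data shown here, with the measured numbers all weak and no measured step to guide the size, the step from compound 2 to compound 4 is expected to be small, a 1.1-fold higher number from compound 2 to compound 4 (0.05 log units; within the scatter), and no direction beyond the scatter is anticipated. Compound 4 is therefore estimated at 25000 nM in this assay. The estimate for compound 4 is expected to fall between 8000 nM and 60000 nM, with a fair chance that this assay reports only a limit for compound 4.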

Compound 4, half-maximal inhibitory concentration: 29200 nM
Compound 4: middle estimate off by 1.2-fold (0.07 log units), on the low side; the range from low to high includes it.
By their numbers in this assay, from the lowest: compounds 3, 2 and 4 (each within the scatter of the next). At a limit, above all of these: compound 1.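

In this assay, going by these compounds alone, the first single change to be read is fluoro in place of cyclopropylmethoxy, on an aromatic carbon para to a large group, and it gives a 1.3-fold higher number from compound 2 to compound 4 (0.12 log units; within the scatter). At this position, then, losing the three-membered ring and the ether oxygen in favour of a lone fluoro does not shift the reading beyond the scatter, so these two groups are not told apart here. Compound 1 still gives only a limit and not a number: the limit of > 40000 nM in this assay, at which 1 of the 4 values shown sits.

As far as these compounds go, what an amine or a carboxylic acid at this same place would do remains open, as does whether any group here can move the number beyond the scatter. How the methoxy groups on the shared core count also stays open, as no step shown isolates them.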